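Replacing the Aryl Group on the Ring Nitrogen Again

The source may hold more compounds than are shown below. What is called first, only, known or untested is meant among the compounds shown, and "the series" means these compounds.

Two measured compounds share one core and differ only in the aromatic group attached to a ring nitrogen. Compound 1 `Oc1cc(C(F)(F)F)ccc1-c1nc(-c2ccccc2O)n(-c2ccc(Br)cc2)n1` carries a 4-bromophenyl group there; in a functional assay on PC-12 cells (Rattus norvegicus) for cytotoxicity, read by MTT assay, with stated times of 2 h and 24 h, tested at 5 uM (a lower number here means a weaker effect, a higher number a stronger effect of the compound at the concentration tested), compound 1 gives 89.8%. Compound 2 `Oc1cc(C(F)(F)F)ccc1-c1nc(-c2ccccc2O)n(-c2cccc(C(F)(F)F)c2)n1` carries a 3-(trifluoromethyl)phenyl group instead, and in this assay compound 2 gives 92.2%. Compound 2 stands close to compound 1: the step of a number 2.4 percentage points higher from compound 1 to compound 2 (within the scatter) is within the scatter, so the two compounds cannot be told apart on this read-out.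

Compound 3 `Oc1cc(C(F)(F)F)ccc1-c1nc(-c2ccccc2O)n(-c2ccc(Cl)cc2Cl)n1` has not yet been measured. It differs from compound 2 in one place: 2,4-dichlorophenyl in place of 3-(trifluoromethyl)phenyl on an aromatic nitrogen. For the measured compounds named here, the only step that bears on this change is the one from compound 1 to compound 2, where exchanging one aromatic group for another on the same ring nitrogen left the number essentially unchanged. The change to compound 3 is of the same kind, a single aromatic group exchanged on that nitrogen, so no step beyond the scatter is expected in this assay. The step of a number 2.2 percentage points lower from compound 2 to compound 3 (within the scatter) is therefore expected to be small. For compound 3 the estimated value in this assay is 90%, with a range from 80% to 97%.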

Compound 3, a percentage reported as activity, at one concentration (the size of the read-out at that concentration, not a potency): 86.7%
Compound 3: middle estimate off by 3.3 percentage points, on the high side; the measured number falls inside the stated range.
By their numbers in this assay, from the lowest: compounds 3, 1 and 2 (each within the scatter of the next).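

In this assay the 2,4-dichlorophenyl group was compared with both earlier aromatic groups on this ring nitrogen: replacing 3-(trifluoromethyl)phenyl gives a number 5.5 percentage points lower from compound 2 to compound 3 (within the scatter) and replacing 4-bromophenyl gives a number 3.1 percentage points lower from compound 1 to compound 3 (within the scatter) on the same read-out. Where the earlier compounds offered a single comparison, there are now three, and none separates its pair, so compounds 1, 2 and 3 cannot be told apart at the one concentration tested, even though the entering group carries chlorine atoms and differs in its substitution from both groups before it. Nothing available explains why these exchanges leave the read-out so similar.

All three groups at this position are substituted phenyl rings bearing halogen or trifluoromethyl, so the compounds shown leave open whether the same holds for a different kind of group there, such as a phenyl ring carrying an amine or a carboxylic acid, or a longer alkyl chain in place of the ring. They also leave open whether differences between these compounds would appear at a lower concentration, where the read-out is a separate question from the one answered here.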